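Swapping the ethoxy group for an anilino group

This account rests on a few compounds, and the source may have more. Where it says the series, first, only, none or still open, it means among the compounds named here.

Compound 1 `CCOC1=C(C(=O)c2ccccc2)C(c2ccc(Br)cc2)N(CCCn2ccnc2)C1=O` and compound 2 `O=C(C1=C(OC2CCCCC2)C(=O)N(CCCn2ccnc2)C1c1ccc(Br)cc1)c1ccccc1` share one core and differ only in the group on the oxygen attached to it. In a functional assay on A549 cells (Homo sapiens) for antiproliferative activity, read by MTT assay, with a stated time of 72 h (on this read-out lower numbers stand for stronger inhibition and higher numbers for weaker inhibition), compound 1 gives 35300 nM, and it stands alongside compound 2, which gives 31200 nM, the two numbers lying within the usual scatter of each other. Among the compounds with values here, the single measured step, a 1.1-fold lower number from compound 1 to compound 2 (0.05 log units; within the scatter), shows that enlarging the group on that oxygen leaves the read-out essentially unchanged. Compound 3 `O=C(C1=C(Nc2ccc(Br)cc2)C(=O)N(CCCn2ccnc2)C1c1ccc(Br)cc1)c1ccccc1` differs from compound 1 by (4-bromophenyl)amino in place of ethoxy on a double-bonded ring carbon. The group that leaves holds an oxygen; the group that enters holds a nitrogen, a hydrogen-bond donor and a six-membered aromatic ring, so the measured step bears on it only loosely and gives no sign of a large shift in either direction. The expected step is a 1.4-fold lower number from compound 1 to compound 3 (0.15 log units; within the scatter), carrying wide uncertainty. Compound 3 is estimated at 25000 nM, within a range from 6000 nM to 80000 nM.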

Compound 3, half-maximal inhibitory concentration: 22200 nM
Beside the measured number, compound 3's estimate is 1.1-fold (0.05 log units) above it; the range from low to high includes it.
By their numbers in this assay, from the lowest: compounds 3, 2 and 1 (each within the scatter of the next).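

In this assay, the ethoxy group and the cyclohexyloxy group can each give way to (4-bromophenyl)amino on the double-bonded ring carbon with the read-out staying within the scatter: a 1.6-fold lower number from compound 1 to compound 3 (0.20 log units; within the scatter) and a 1.4-fold lower number from compound 2 to compound 3 (0.15 log units; within the scatter). The earlier pair changed only the group on the oxygen, whereas this change replaces the oxygen link with a nitrogen carrying a hydrogen-bond donor and an aromatic ring, and even this larger change does not separate the compounds. No measurement here explains this outcome.

From the compounds shown here alone, it remains open whether any group on this carbon can move the number beyond the scatter, for example a carboxylic acid or a small amine such as dimethylamino. The nitrogen, the aromatic ring and the bromine enter together, so the compounds shown cannot separate their individual contributions.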